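Nitro for methoxy on a sulfonate aryl: expected growth inhibition

The source may hold more compounds than are shown below. What is called first, only, known or untested is meant among the compounds shown, and "the series" means these compounds.

Of the compounds shown here, three have been measured in a functional assay on HL-60 cells (Homo sapiens) for inhibition, read by CCK-8 assay, with a stated time of 48 h, tested at 20 uM; a higher number here means more inhibition of growth at the concentration tested, a lower number less inhibition of growth. Compound 1 `COc1ccc(Cc2nnc(NC(=O)/C(C#N)=C/c3ccccc3OS(=O)(=O)c3ccc(OC)cc3)s2)cc1` gives 100%. Compound 2 `COc1ccc(Cc2nnc(NC(=O)/C(C#N)=C/c3ccccc3OS(=O)(=O)c3ccc([N+](=O)[O-])cc3)s2)cc1` gives 51%. Compound 3 `COc1ccc(S(=O)(=O)Oc2ccccc2/C=C(\C#N)C(=O)Nc2nnc(Cc3cccc(F)c3)s2)cc1` gives 100%.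

Compound 1 and compound 2 differ by nitro in place of methoxy on an aromatic carbon. This change is accompanied by a number 49 percentage points lower from compound 1 to compound 2 (beyond the scatter). Compound 1 and compound 3 differ in their cores by 3-fluorophenyl in place of 4-methoxyphenyl on a saturated chain carbon bound to an aromatic carbon; here the result is no change at the digits printed from compound 1 to compound 3 (within the scatter), so compound 3 stands level with compound 1 and both sit far above compound 2.

Compound 4 `N#C/C(=C\c1ccccc1OS(=O)(=O)c1ccc([N+](=O)[O-])cc1)C(=O)Nc1nnc(Cc2cccc(F)c2)s1` has not yet been measured in this assay. It differs from compound 3 by nitro in place of methoxy on an aromatic carbon. The place of the change in compound 3 is described in the same words as the place of the change in compound 1, so it is the same change made on the core of compound 3 rather than on the core of compound 1. Because the same change produced a number 49 percentage points lower from compound 1 to compound 2 (beyond the scatter), and because the two cores behave alike as shown by no change at the digits printed from compound 1 to compound 3 (within the scatter), a drop of comparable size is expected here, which would read as a number 48 percentage points lower from compound 3 to compound 4 (beyond the scatter). Among the measured compounds shown here, with only one earlier instance of this change to rest on, the expected value carries a wide range. For compound 4 in this assay the estimate is 52%, expected to lie between 30% and 75%.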

Compound 4, percent growth inhibition at one concentration: 18%
Compound 4: middle estimate off by 34 percentage points, on the high side; measured number below the stated range.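

In this assay, nitro in place of methoxy lowers the number on both cores, but the fall on the core of compound 3 is the larger one (a number 82 percentage points lower from compound 3 to compound 4 (beyond the scatter)), so the direction of this change carries from one core to the other while its size does not: the same change on two cores in this assay, a number 49 percentage points lower (beyond the scatter) from compound 1 to compound 2 and a number 82 percentage points lower (beyond the scatter) from compound 3 to compound 4, 33 percentage points apart, beyond the scatter of two such steps. Read the other way, 3-fluorophenyl in place of 4-methoxyphenyl leaves the number unchanged when methoxy is present but not when nitro is (a number 33 percentage points lower from compound 2 to compound 4 (beyond the scatter)), so the two changes cannot be treated as adding up independently in this series: the same change on two cores in this assay, no change at the digits printed (within the scatter) from compound 1 to compound 3 and a number 33 percentage points lower (beyond the scatter) from compound 2 to compound 4, 33 percentage points apart, beyond the scatter of two such steps. This rests on one pair of cores at a single concentration, and it shows neither why the steps differ nor how large the gap between the cores would be at other concentrations, since compound 1 and compound 3 give the same number.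

The compounds shown leave open whether the larger fall belongs to the fluorine or to the loss of the methoxy on the phenyl ring, which unsubstituted phenyl in place of 4-methoxyphenyl could help separate. They also leave open how an amine or a methyl group in place of methoxy or nitro would behave on either core.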